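The source may report more compounds than this note shows. Statements on the series, on what has been measured and on what is new or still open speak of the compounds shown alone.

Three compounds of the series carry a measurement in a functional assay with platelet-activating factor receptor (Cavia porcellus) as the target; a higher number here means that more compound is needed for the effect, a lower number that less compound is needed. Compound 1 `O=C(/C=C/C=C(c1ccc(F)cc1)c1ccc(F)cc1)NCCCCc1cccnc1` gives 0.38 mg/kg. Compound 2 `CC/C(=C\C=C\C(=O)N[C@H](C)CCCc1cccnc1)c1ccc(OC)cc1` gives 0.68 mg/kg, the highest of the three numbers; compound 1 sits within the scatter of it, compound 3 lies beyond it. Compound 3 `COc1cccc(C(=C/C=C/C(=O)N[C@H](C)CCCc2cccnc2)c2cccc(OC)c2)c1` gives 0.21 mg/kg, the lowest of the three. No two of these compounds differ in a single place, so no step can be read from them directly.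

Compound 4 `COc1ccc(/C(=C/C=C/C(=O)N[C@H](C)CCCc2cccnc2)C(C)C)cc1` has not been measured. Relative to compound 2 the change is methyl in place of hydrogen on a saturated chain carbon bound to a double-bonded chain carbon and a saturated chain carbon. Within the data shown here, none of the measured compounds differs from another by a methyl on a saturated chain carbon, so the measured numbers say nothing about this change on their own. A step within the usual scatter is expected, in either direction, with no ground for preferring one side. For compound 4 the expected value in this assay is 0.6 mg/kg, within a range of 0.3 mg/kg to 1.4 mg/kg. The step this estimate means is a 1.1-fold lower number from compound 2 to compound 4 (0.05 log units; within the scatter), expected to remain within the scatter.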

Compound 4, dose for 50% inhibition: 0.41 mg/kg
Beside the measured number, compound 4's estimate is 1.5-fold (0.17 log units) above it, and the stated range covers the measured number.
By their numbers in this assay, from the lowest: compounds 3, 1, 4 and 2 (each within the scatter of the next, the first and the last beyond it).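

In this assay the series now has its first step that can be read at a single place: methyl in place of hydrogen on a saturated chain carbon bound to a double-bonded chain carbon and a saturated chain carbon, which turns ethyl into isopropyl, gives a 1.7-fold lower number from compound 2 to compound 4 (0.22 log units; within the scatter) and so stays within the scatter. In this one pair, the added methyl therefore leaves the dose for the effect indistinguishable from that of the ethyl compound, and neither a gain nor a loss can be assigned to it. Nothing at hand bears on why the step has this size.

Open, going by these compounds, is whether this carbon would give a step of similar size with a longer chain, such as a tert-butyl group, or with a hydroxyl group in place of the methyl. Also open, on these data alone, is whether the same change would give a similar step on a different aryl substitution.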